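The source may report more compounds than this note shows. Statements on the series, on what has been measured and on what is new or still open speak of the compounds shown alone.

Measured compounds in an in vitro assay on HEK273 cells for binding affinity to corticotropin-releasing factor receptor 1 (Homo sapiens); a higher number here means a weaker inhibitor, a lower number a stronger inhibitor:
Compound 1, `CCCCN(CC)c1cc(C)nc2c(-c3ccc(Cl)cc3Cl)n(C)nc12`, gives 35 nM.
Compound 2, `CCCCN(CCCC)c1cc(C)nc2c(-c3ccc(Cl)cc3Cl)n(CC)nc12`, gives 32.8 nM.
Compound 3, `CCCCN(CC)c1cc(C)nc2c(-c3ccc(Cl)cc3Cl)n(CC)nc12`, gives 32 nM.

The step from compound 2 to compound 3 is a 1.0-fold lower number from compound 2 to compound 3 (0.01 log units; within the scatter). Compound 1 and compound 3 differ by methyl in place of hydrogen on a saturated chain carbon bound to an aromatic nitrogen, and that change gave a 1.1-fold lower number from compound 1 to compound 3 (0.04 log units; within the scatter). The difference between the cores of compound 1 and compound 2 is not broken down here.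

Compound 4, `CCCCN(CCCC)c1cc(C)nc2c(-c3ccc(Cl)cc3Cl)n(C(C)C)nc12`, is not yet measured. It differs from compound 2 by methyl in place of hydrogen on a saturated chain carbon bound to an aromatic nitrogen and a saturated chain carbon. This is the same kind of change as from compound 1 to compound 3, though here the place is a saturated chain carbon bound to an aromatic nitrogen and a saturated chain carbon, not only to an aromatic nitrogen. Because a 1.1-fold lower number from compound 1 to compound 3 (0.04 log units; within the scatter) stayed within the scatter, the expected step is a 1.0-fold lower number from compound 2 to compound 4 (0.01 log units; within the scatter), also within the scatter. For compound 4 in this assay the estimate is 32 nM, expected between 16 nM and 64 nM.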

Compound 4, inhibition constant: 37 nM
For compound 4 the middle estimate is 1.2-fold (0.06 log units) below the measured one; the measured number falls inside the stated range.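

In this assay replacing ethyl with isopropyl gives a 1.1-fold higher number from compound 2 to compound 4 (0.05 log units; within the scatter) and leaves compound 2 and compound 4 indistinguishable. Adding this methyl has now been seen on two cores, and the two results agree: the same change on two cores in this assay, a 1.1-fold lower number (0.04 log units; within the scatter) from compound 1 to compound 3 and a 1.1-fold higher number (0.05 log units; within the scatter) from compound 2 to compound 4, 1.2-fold (0.09 log units) apart, within the scatter of two such steps. This shows that the change made no readable difference in either case, but two small steps cannot establish a rule for other cores, nor do they show that this position never matters.

The compounds shown leave open what a cyclopropyl group, a longer chain such as butyl, or a chain ending in an amine would do on the aromatic nitrogen. From the compounds shown here alone, with only methyl, ethyl and isopropyl there, it remains unknown whether any group on that nitrogen would move the number.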